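Cytotoxicity notes: benzyloxy in place of isobutoxy

The source may report more compounds than this note shows. Statements on the series, on what has been measured and on what is new or still open speak of the compounds shown alone.

For the measured compounds named here, the two measured members share one core. Compound 1 `CCOC(=O)CCCCCOc1cccc(CN(C(=O)c2ccc(-c3cccc(NC(C)=O)c3)cc2)C(C)C)c1` carries an acetamido group on its pendant aromatic ring. In an ADME assay on BJ cells (Homo sapiens) for cytotoxicity, read by CellTiter-Glo and resazurin assay, with a stated time of 72 h (on this read-out lower numbers stand for an effect already at smaller amounts and higher numbers for an effect only at larger amounts of compound), compound 1 reaches only the assay limit > 26000 nM. Compound 2 `CCOC(=O)CCCCCOc1cccc(CN(C(=O)c2ccc(-c3cccc(OCC(C)C)c3)cc2)C(C)C)c1` carries isobutoxy in that place. In this assay compound 2 likewise gives only the limit > 26000 nM. The step that the two limits leave unreadable from compound 1 to compound 2 is therefore of no readable size. Compound 2 stands at the limit of > 26000 nM in this assay, at which 2 of the 2 values shown sit, with nothing more on it than that limit.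

Compound 3 `CCOC(=O)CCCCCOc1cccc(CN(C(=O)c2ccc(-c3cccc(OCc4ccccc4)c3)cc2)C(C)C)c1` differs from compound 2 by phenyl in place of isopropyl on a saturated chain carbon bound to an oxygen on an aromatic ring. No measured step bears on this change: the one step shown is unreadable, and both values sit at the limit. For compound 3 the expected step is a step that the limit leaves unreadable from compound 2 to compound 3, that is nothing beyond the scatter in this assay. Compound 3 is therefore expected to give about 30000 nM, between 10000 nM and 100000 nM, most likely again as a limit in this assay.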

Compound 3, half-maximal effective concentration: > 26000 nM
Compound 3 ended at the assay's limit; the forecaster's own chance of this, stated with the estimate: 80%; the middle value lies beyond the limit too.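

Compound 3 gives only a limit in this assay, as do compound 1 and compound 2, so no step among these compounds can be read: the limit of > 26000 nM in this assay, at which 3 of the 3 values shown sit.

The compounds shown leave open whether acetamido, isobutoxy and benzyloxy differ at all in this assay.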